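Solubility of the amide series: pyridin-3-yl variant

The source may report more compounds than this note shows. Statements on the series, on what has been measured and on what is new or still open speak of the compounds shown alone.

Compound 3 `COc1ccc2nc(C)cc(OCC(=O)Nc3ccc(Cl)cc3)c2c1` gives 9000 nM in a physicochemical assay for solubility, in phosphate buffer, measured as kinetic solubility, with a stated time of 1 h, at pH 7.4 (a lower number here means a less soluble compound, a higher number a more soluble compound), the lowest of the two numbers shown. Compound 1 `COc1cccc(NC(=O)COc2cc(C)nc3ccc(OC)cc23)c1` gives 35000 nM in this assay. Compound 2 `COc1ccc2nc(C)cc(OCC(=O)Nc3ccc(Br)c(C)c3)c2c1` gives < 1000 nM in this assay, which is a limit of the assay and not a number (the limit of < 1000 nM in this assay, at which 1 of the 3 values shown sits). The steps measured so far all sit on the amide-type nitrogen: a 3.9-fold lower number from compound 1 to compound 3 (0.59 log units; beyond the scatter), an at least 9.0-fold higher number from compound 2 to compound 3 (0.95 log units; beyond the scatter), and an at least 35-fold lower number from compound 1 to compound 2 (1.54 log units; beyond the scatter). Compound 4 `COc1ccc2nc(C)cc(OCC(=O)Nc3cccnc3)c2c1` differs from compound 3 in the same place: pyridin-3-yl in place of 4-chlorophenyl on an amide-type nitrogen. Among the measured compounds shown here, no measured step carries a pyridin-3-yl, so the size of the change rests on the range seen in the three steps, which run from modest to large. Compound 4 is expected to come out at 40000 nM in this assay, within 12000 nM to 130000 nM. The expected step is a 4.4-fold higher number from compound 3 to compound 4 (0.65 log units; beyond the scatter), a higher number in the direction of compound 1, where the step of a 3.9-fold lower number from compound 1 to compound 3 (0.59 log units; beyond the scatter) shows the amide-type nitrogen substituent moving the solubility by a modest amount.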

Compound 4, solubility: 32000 nM
For compound 4 the middle estimate is 1.3-fold (0.10 log units) above the measured one, within the range that was stated.
By their numbers in this assay, from the lowest: compound 3; then compounds 4 and 1 (each within the scatter of the next). At a limit, below all of these: compound 2.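

In this assay, pyridin-3-yl is the only ring with a hetero atom shown on the amide-type nitrogen, and it gives a 3.6-fold higher number from compound 3 to compound 4 (0.55 log units; beyond the scatter) and a 1.1-fold lower number from compound 1 to compound 4 (0.04 log units; within the scatter), so this ring and 3-methoxyphenyl cannot be told apart here. Compound 2 stays at a limit of the assay and not a number: the limit of < 1000 nM in this assay, at which 1 of the 4 values shown sits. Read against that limit, the same change gives an at least 32-fold higher number from compound 2 to compound 4 (1.50 log units; beyond the scatter), which is a bound only.

Going from compound 3 to compound 4 removes the chlorine and brings in the ring nitrogen together, so the compounds shown cannot separate the two. Also open, as far as these compounds go, is how a 5-chloropyridin-3-yl, a pyridin-4-yl or a phenyl ring carrying a carboxylic acid or a dimethylamino group would read at this place.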